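This account rests on a few compounds, and the source may have more. Where it says the series, first, only, none or still open, it means among the compounds named here.

Working notes on the series. Among the compounds with values here, compound 1 `COc1cc(-n2cnc3ccc(-c4cccc([N+](=O)[O-])c4)cc32)cc(OC)c1OC` gives 380 nM in a functional assay on SGC-7901 cells (Homo sapiens) for antiproliferative activity, read by MTT assay, with a stated time of 72 h (a higher number here means a weaker inhibitor, a lower number a stronger inhibitor), and is the only member with a numeric result. Compound 2 `COc1cc(-n2cnc3ccc(-c4ccc(O)cc4)cc32)cc(OC)c1OC` returns only a limit of the assay, > 10000 nM in this assay. Within the data shown here, the one measured step, an at least 26-fold higher number from compound 1 to compound 2 (1.42 log units; beyond the scatter), therefore ends at the limit (the limit of > 10000 nM in this assay, at which 1 of the 2 values shown sits), so compound 2 stands at the weak edge of the series with no numeric value to anchor it.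

Compound 3 `CCOc1ccc(-c2ccc3ncn(-c4cc(OC)c(OC)c(OC)c4)c3c2)cc1` differs from compound 2 by ethyl in place of hydrogen on an oxygen on an aromatic ring. Among the measured compounds shown here, no measured step concerns this kind of change; the only measured step, an at least 26-fold higher number from compound 1 to compound 2 (1.42 log units; beyond the scatter), involves a different exchange and does not transfer directly. The step of an at least 2.5-fold lower number from compound 2 to compound 3 (0.39 log units; beyond the scatter) is therefore only an expectation, and a loose one.

Compound 3 is estimated at 4000 nM in this assay, expected within 500 nM to 20000 nM.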

Compound 3, half-maximal inhibitory concentration: 2970 nM
The estimate for compound 3 lay 1.3-fold (0.13 log units) above the measured number; the range from low to high includes it.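

Ethyl on the oxygen of the 4-hydroxyphenyl group turns a limit into a numeric result in this assay, with an at least 3.3-fold lower number from compound 2 to compound 3 (0.52 log units; beyond the scatter), so a free hydroxy hydrogen at this place is not required for measurable activity. The value at the start of that step, held by compound 2, is a limit of the assay: the limit of > 10000 nM in this assay, at which 1 of the 3 values shown sits.

The 4-ethoxyphenyl group still does not match the 3-nitrophenyl group, with a 7.8-fold higher number from compound 1 to compound 3 (0.89 log units; beyond the scatter), so this aromatic carbon now has a numeric comparison, and it favours 3-nitrophenyl.

Going by these compounds, whether the ethyl itself matters, or any group on that oxygen would serve, stays open, as does the effect of a methoxy, a longer chain or an amine there. The 3-nitrophenyl and 4-ethoxyphenyl groups differ in both substituent and ring place, so neither difference can be credited alone.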